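Replacing an ester chain with a toluoyl amide

The source may hold more compounds than are shown below. What is called first, only, known or untested is meant among the compounds shown, and "the series" means these compounds.

Two close relatives of the shared core have been tested in an ADME assay on HepG2 2.2.15 cells (Homo sapiens) for cytotoxicity; on this read-out higher numbers stand for lower toxicity in this test and lower numbers for higher toxicity in this test. Compound 1 (`CC(C)(C)OC(=O)Nc1ncc(C(Oc2ccc(Br)cc2)c2ccc(Cl)cc2)s1`) carries a tert-butoxycarbonyl group on the ring nitrogen. In this assay compound 1 reaches only the limit of the test, > 50000 nM, and no number is given; this is the limit of > 50000 nM in this assay, at which 1 of the 2 values shown sits. Compound 2 (`CCOC(=O)CCCNc1ncc(C(Oc2ccc3cc(Br)ccc3c2)c2ccc(Cl)cc2)s1`) is recorded in this assay as "not toxic" (no number reported), again without a number, so compound 2 stands at the untoxic end of what the test can show.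

Compound 3 (`Cc1ccc(C(=O)Nc2ncc(C(Oc3ccc4cc(Br)ccc4c3)c3ccc(Cl)cc3)s2)cc1`) differs from compound 2 in one place: (4-methylphenyl)carbonyl in place of 3-(ethoxycarbonyl)propyl on a nitrogen on an aromatic ring. Among the compounds with values here, no measured step connects these two, so the expected size of this change in this assay cannot be drawn from a comparison; with both measured compounds sitting at the untoxic end, no movement beyond the usual scatter is expected. Compound 3 is therefore estimated at 50000 nM, within 15000 nM to 100000 nM.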

Compound 3, half-maximal cytotoxic concentration: "not toxic" (no number reported)
Compound 3: no number reported; no gap can be computed for the estimate.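

Compound 2 and compound 3 are both recorded as "not toxic" in this assay without a number, so no step can be read between them. The compounds shown leave open at what concentration, if any, each would become toxic to these cells: the limit of > 50000 nM in this assay, at which 1 of the 3 values shown sits.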